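A few compounds are considered here, and "the series" means these few. Any claim that something is new, unique, unknown or untested is made for them only; others in the source may bear on it.

Working notes on the series. The shared core is seen in compound 1 `Oc1cccc(CNc2cc(Br)cc3[nH]ncc23)c1`, which gives 45% in an assay for inhibition of Indoleamine 2,3-dioxygenase 1 (Homo sapiens), with a stated time of 1 h, tested at 10 uM; on this read-out higher numbers stand for more inhibition at the one concentration tested (going by the name of the read-out) and lower numbers for less inhibition. Compound 2 `ONc1cccc(CNc2cc(Br)cc3[nH]ncc23)c1` gives 53%, and compound 3 `Oc1ccc(CNc2cc(Br)cc3[nH]ncc23)c(O)c1` gives 40%. Compound 2 therefore holds the highest of the three numbers, though its gap to compound 1 stays within the scatter and only its gap to compound 3 lies beyond it. Compound 4 `CCOC(=O)Nc1cccc(CNc2cc(Br)cc3[nH]ncc23)c1` carries ethoxycarbonyl in place of hydroxy on a nitrogen on an aromatic ring. Among the compounds with values here, the only measured step at that position is a number 8 percentage points higher from compound 1 to compound 2 (within the scatter), which concerns a change on the aromatic carbon rather than on the nitrogen, so it bears only loosely. With nothing closer to go on, a small step downward or none beyond the scatter is expected, a number 8 percentage points lower from compound 2 to compound 4 (within the scatter). Compound 4 is estimated at 45%, between 20% and 68%.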

Compound 4, a percentage reported as inhibition, at one concentration (the size of the read-out at that concentration, not a potency): 29%
Compound 4: the middle estimate sits 16 percentage points above what was measured, within the range that was stated.
By their numbers in this assay, from the lowest: compound 4; then compounds 3, 1 and 2 (each within the scatter of the next, the first and the last beyond it).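

In this assay, within the data shown here, ethoxycarbonyl in place of hydroxy on a nitrogen on an aromatic ring gives a number 24 percentage points lower from compound 2 to compound 4 (beyond the scatter), the first step at this position that lies beyond the scatter. The comparison with the hydroxy of the shared core points the same way, with a number 16 percentage points lower from compound 1 to compound 4 (beyond the scatter), so the read-out here is not indifferent to the group carried. No measurement on hand accounts for these steps. Still open, on these data alone, is whether the lower number follows the carbonyl or the ethyl part. A plain amine or an acetyl group on that nitrogen would separate these readings.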